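Adding a Fluorine to the Aryl Ring of Compound 2

The source may hold more compounds than are shown below. What is called first, only, known or untested is meant among the compounds shown, and "the series" means these compounds.

Two compounds have numbers in a functional assay on MKN-45 cells (Homo sapiens) for cytotoxicity, read by MTT assay, with a stated time of 72 h; on this read-out higher numbers stand for weaker inhibition and lower numbers for stronger inhibition. Compound 1 (`Fc1cc(Nc2cc(Nc3cccc(Cl)c3)ncn2)ccc1Oc1ccncc1-c1cccnc1`) gives 30 nM in this assay. Compound 2 (`Cn1c(=O)c(C(=O)Nc2ccc(Oc3ccncc3-c3cccnc3)c(F)c2)nn(-c2ccc(Cl)cc2)c1=O`) gives 1600 nM in this assay, the higher of the two numbers, with compound 1 standing well below it, beyond the scatter. The two structures differ in more than one place, so the gap between them is taken only as what the two values show and not as a single step.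

Compound 3 (`Cn1c(=O)c(C(=O)Nc2ccc(Oc3ccncc3-c3cccnc3)c(F)c2)nn(-c2ccc(F)c(Cl)c2)c1=O`) has not been measured. It differs from compound 2 in one place: 3-chloro-4-fluorophenyl in place of 4-chlorophenyl on an aromatic nitrogen. Among the measured compounds shown here, no pair of measured compounds differing in a single place is available, so nothing measured speaks directly to a change of this kind. The expectation for compound 3 therefore rests on the value of compound 2, 1600 nM, as its starting point. The expected step, a 1.3-fold lower number from compound 2 to compound 3 (0.12 log units; within the scatter), is one that stays within the scatter, with no clear direction. Compound 3 is expected to give about 1200 nM in this assay, within a range from 400 nM to 3500 nM.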

Compound 3, half-maximal inhibitory concentration: 10100 nM
The estimate for compound 3 lay 8.4-fold (0.93 log units) below the measured number, outside the stated range (above it).
By their numbers in this assay, from the lowest: compound 1; then compound 2; then compound 3.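

The aryl group on the aromatic nitrogen is not a silent place in this assay: 3-chloro-4-fluorophenyl in place of 4-chlorophenyl gives a 6.3-fold higher number from compound 2 to compound 3 (0.80 log units; beyond the scatter). This is the first single-place step among these compounds, and it shows that a small change on this ring can move the number beyond the scatter, even though the ring itself stays and no hydrogen-bond donor or acceptor enters or leaves. Here the two halogens as placed in compound 3 go with weaker inhibition than the single chlorine of compound 2, though nothing at hand accounts for the direction or size of this step.

The change alters two things at once, the place of the chlorine and the presence of a fluorine, so the compounds shown leave open which of them carries the step, and a phenyl bearing fluorine alone would speak to that. Also open, going by these compounds, is how this position would respond to a group of another kind on the phenyl ring, such as a methoxy group or an amine, or to an unsubstituted phenyl.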